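Swapping Fluorine for Chlorine on the Benzoyl Ring

The source may hold more compounds than are shown below. What is called first, only, known or untested is meant among the compounds shown, and "the series" means these compounds.

Compound 1: `CCC(=O)N(C)c1ccc2[nH]c(-c3n[nH]c4ccccc34)cc2n1` — 6130 nM
Compound 2: `CN(C(=O)c1ccc(F)cc1)c1ccc2[nH]c(-c3n[nH]c4ccccc34)cc2n1` — 1210 nM

Both compounds were tested in a functional assay on HL-60 cells (Homo sapiens) for antiproliferative activity, read by MTT assay, with a stated time of 72 h; a higher number here means a weaker inhibitor, a lower number a stronger inhibitor. Compound 1 gives 6130 nM, while compound 2 gives 1210 nM, the lower of the two numbers. Among the compounds with values here, the one step measured so far, a 5.1-fold lower number from compound 1 to compound 2 (0.70 log units; beyond the scatter), came from putting a 4-fluorophenyl in place of ethyl on the carbonyl carbon.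

The next compound, compound 3, is `CN(C(=O)c1ccc(Cl)cc1)c1ccc2[nH]c(-c3n[nH]c4ccccc34)cc2n1`. It differs from compound 2 only in this way: chloro in place of fluoro on an aromatic carbon. Within the data shown here, no measured step here changes one halogen for another on an aromatic carbon, so the one step in hand, from compound 1 to compound 2, does not bear directly on this change; it only shows that the aryl group on the carbonyl matters for this assay. With nothing to suggest a large shift either way, compound 3 is expected to land close to compound 2, within the usual scatter, the expected step being a 1.3-fold lower number from compound 2 to compound 3 (0.11 log units; within the scatter). The estimate for compound 3 in this assay is 950 nM, with a range from 350 nM to 2600 nM.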

Compound 3, half-maximal inhibitory concentration: 450 nM
Beside the measured number, compound 3's estimate is 2.1-fold (0.32 log units) above it; the range from low to high includes it.
By their numbers in this assay, from the lowest: compound 3; then compound 2; then compound 1.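

In this assay, the earlier pair showed only that a 4-fluorophenyl on the carbonyl gives a lower number than ethyl, and the new result shows that the halogen on that ring matters as well. Chloro in place of fluoro gives a 2.7-fold lower number from compound 2 to compound 3 (0.43 log units; beyond the scatter), so exchanging one heavy atom for one other heavy atom at this place on the ring is enough to move the number past the usual scatter. Measured against the ethyl compound, 4-chlorophenyl in place of ethyl gives a 14-fold lower number from compound 1 to compound 3 (1.13 log units; beyond the scatter), a large step, so how much an aryl group on the carbonyl gains in this assay depends on what that ring carries. Nothing available here explains why the two halogens differ.

With only two halogens shown at this place, it remains open whether the number would keep falling with bromo or iodo, or whether a methyl, a methoxy or a plain hydrogen in the same place would match chloro. From the compounds shown here alone, it is also open whether chloro would give the same result at another carbon of the ring, or whether the gain would survive a change elsewhere, such as a longer chain in place of the methyl on the amide nitrogen.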